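Methoxy on the aryl ring of thiosemicarbazones

This account rests on a few compounds, and the source may have more. Where it says the series, first, only, none or still open, it means among the compounds named here.

Compound 1 `CC1=CC[C@H](C(C)(C)NC(=S)N/N=C/c2ccc(O)cc2)CC1` bears a hydroxyphenyl aldehyde-derived thiosemicarbazone. In a functional assay on UACC-62 cells (Homo sapiens) for inhibition, read by sulforhodamine B assay, with a stated time of 48 h (on this read-out higher numbers stand for weaker inhibition of growth and lower numbers for stronger inhibition of growth), compound 1 reaches only a limit of the assay, > 100000 nM. Compound 2 `COc1cc(/C=N/NC(=S)NC(C)(C)[C@H]2CC=C(C)CC2)ccc1O` differs from compound 1 by methoxy in place of hydrogen on an aromatic carbon. In this assay compound 2 gives 14700 nM, and the step of an at least 6.8-fold lower number from compound 1 to compound 2 (0.83 log units; beyond the scatter) is the one measured change of this kind in the series. Compound 3 `CC1=CC[C@H](C(C)(C)NC(=S)N/N=C(\C)c2ccccc2)CC1` carries a different core; how its core differs from that of compound 1 is not broken down here. In this assay compound 3 also stops at a limit of the assay, > 100000 nM. Of the three values shown, two sit at the limit of > 100000 nM in this assay, at which 2 of the 3 values shown sit.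

Compound 4 `COc1ccc(/C(C)=N/NC(=S)NC(C)(C)[C@H]2CC=C(C)CC2)cc1` is still to be measured in this assay. It differs from compound 3 by methoxy in place of hydrogen on an aromatic carbon. This is the same kind of change as from compound 1 to compound 2, not the same: there the methoxy sits ortho to a hydroxy group and meta to a large group, here para to a large group, with no hydroxy present. Resting on the step of an at least 6.8-fold lower number from compound 1 to compound 2 (0.83 log units; beyond the scatter), a step of about an at least 1.6-fold lower number from compound 3 to compound 4 (0.22 log units; that floor lies within the scatter) is expected from compound 3 to compound 4, though the start from a limit leaves it uncertain. For compound 4 a value around 60000 nM is estimated, from 15000 nM to 200000 nM.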

Compound 4, concentration for 50% growth inhibition: 95300 nM
Estimate against measurement, compound 4: 1.6-fold (0.20 log units) below; measured number inside the range.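

Compound 3 stands only at a limit of this assay, > 100000 nM. Starting from that limit, methoxy in place of hydrogen gives an at least 1.0-fold lower number from compound 3 to compound 4 (0.02 log units; that floor lies within the scatter), so the change is seen to leave a measurable number on this core as well, but the true size of the step stays unknown. The methoxy also sits para to a large group here with no hydroxy present, so this pair does not show whether the larger step on the core of compound 1 carries over, nor that it fails to: the same change on two cores in this assay, an at least 6.8-fold lower number (0.83 log units; beyond the scatter) from compound 1 to compound 2 and an at least 1.0-fold lower number (0.02 log units; that floor lies within the scatter) from compound 3 to compound 4; the limit leaves it open whether they differ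

Still open, on these data alone, is how a core with both hydroxy and methoxy on the ring would behave when built on the core of compound 3, and whether an ethoxy group, a fluorine atom or an amine in the place of the methoxy would read differently. Any such comparison in this series is also limited by how many values reach no number at all: the limit of > 100000 nM in this assay, at which 2 of the 4 values shown sit.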